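Isopropyl for dimethylamino on the carbonyl carbon

The source may report more compounds than this note shows. Statements on the series, on what has been measured and on what is new or still open speak of the compounds shown alone.

Notes on a small series sharing one core, read in an ADME assay on microsomes from liver (Mus musculus) for metabolic stability, with a stated time of 30 min; on this read-out lower numbers stand for a less stable compound and higher numbers for a more stable compound. For compound 1 `COC(=O)C(=O)N[C@@H](CO)C(=O)O` the result is "not determined" (no result reported), so it adds no number to the comparison. Compound 2 `O=C(CCO)N[C@@H](CO)C(=O)O` gives 87% and compound 3 `CN(C)C(=O)N[C@@H](CO)C(=O)O` gives 30%, which makes compound 3 the lower of the two numbers available. For the measured compounds named here, the only measured step, a number 57 percentage points lower from compound 2 to compound 3 (beyond the scatter), is large and beyond the scatter. It puts dimethylamino in place of 2-hydroxyethyl on a carbonyl carbon.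

Compound 4 `CC(C)C(=O)N[C@@H](CO)C(=O)O` is not yet measured. It carries isopropyl in place of dimethylamino on a carbonyl carbon, (isopropyl in place of dimethylamino on a carbonyl carbon). Going by the values given here, the measured step bears on this change only in part: the place is the same and dimethylamino is again the group concerned, but here it leaves, and no measured compound carries isopropyl. The expectation therefore rests on compound 2 at 87% as the one higher reference point, and a rise of moderate size is expected, smaller than the measured step and uncertain in extent. The expected step is a number 25 percentage points higher from compound 3 to compound 4 (beyond the scatter). For compound 4 the estimated value is 55%, with an expected range of 30% to 85%.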

Compound 4, percent of the compound remaining: 49%
For compound 4 the middle estimate is 6 percentage points above the measured one, within the range that was stated.
By their numbers in this assay, from the lowest: compound 3; then compound 4; then compound 2.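

In this assay, the change on a carbonyl carbon whose other neighbours are amide-type nitrogen gives a number 19 percentage points higher from compound 3 to compound 4 (beyond the scatter) for isopropyl in place of dimethylamino, so this position also responds between two groups with the same heavy-atom count and no hydrogen-bond donors or acceptors, where isopropyl is all carbon and dimethylamino holds a nitrogen. The second comparison, a number 38 percentage points lower from compound 2 to compound 4 (beyond the scatter) for isopropyl in place of 2-hydroxyethyl, shows that removing dimethylamino recovers only part of the gap to the highest number in the series, and that nitrogen-free groups at this position do not all read alike. No supporting data are available to explain either step.

The compounds shown leave open whether ethyl, which lacks the hydroxyl of 2-hydroxyethyl, would read closer to compound 2 or to compound 4, and so whether that hydroxyl or the chain itself goes with the higher number. Going by these compounds, how a longer chain, such as 3-hydroxypropyl, or a cyclic amine such as morpholine would read on the same carbonyl carbon also remains open.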